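Shortening the Chain of a Hydroxamic Acid Inhibitor

This account rests on a few compounds, and the source may have more. Where it says the series, first, only, none or still open, it means among the compounds named here.

Of the compounds shown here, three sharing one core have been tested in an assay on isolated protein for inhibition of histone deacetylase 8 (Homo sapiens), read by fluorescence; a lower number here means a stronger inhibitor, a higher number a weaker inhibitor. Compound 1 `C#CCN(C)CCCOc1cc(NCc2ccc(/C=C/C(=O)NO)cc2)ccc1Cl` gives 80 nM. Compound 2 `C#CCN(C)CCCOc1cc(NC(=O)CCCCCCCC(=O)NO)ccc1Cl` gives 1120 nM, and compound 3 `C#CCN(C)CCCOc1cccc(NC(=O)CCCCCCC(=O)NO)c1Cl` gives 1470 nM. Compound 2 thus stands second highest of the three numbers; its value and that of compound 3 lie within the scatter of each other, while compound 1 lies well beyond the scatter at the stronger end. Compound 4 `C#CCN(C)CCCOc1cc(NC(=O)CCCCCCC(=O)NO)ccc1Cl` is not yet measured. It differs from compound 2 in one place: hydroxycarbamoyl in place of (hydroxycarbamoyl)methyl on a saturated chain carbon, six bonds along the chain from a carbonyl carbon. Within the data shown here, no measured pair shows this exact step. Compound 3, which carries the shorter chain, gives 1470 nM. Because compound 3 shows 1470 nM, compound 4 is expected to move only within the scatter, a step of a 1.1-fold higher number from compound 2 to compound 4 (0.03 log units; within the scatter). Compound 4 is estimated at 1200 nM, ranging from 500 nM to 3000 nM.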

Compound 4, half-maximal inhibitory concentration: 50 nM
Estimate against measurement, compound 4: 24-fold (1.38 log units) above; measured number below the stated range.
By their numbers in this assay, from the lowest: compounds 4 and 1 (each within the scatter of the next); then compounds 2 and 3 (each within the scatter of the next).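

In this assay, putting hydroxycarbamoyl in place of (hydroxycarbamoyl)methyl shortens the chain and gives a 22-fold lower number from compound 2 to compound 4 (1.35 log units; beyond the scatter) and this large step lies beyond the scatter. Chain length at this place, six bonds along the chain from a carbonyl carbon, therefore has a strong effect on the number, which no earlier pair could show. Nothing available here explains the size of this step. As far as these compounds go, whether a still shorter chain would keep this strength remains open. So does the effect of a carboxylic acid in place of hydroxycarbamoyl.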